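This account rests on a few compounds, and the source may have more. Where it says the series, first, only, none or still open, it means among the compounds named here.

Compound 1 `CCC(C)(C)C(=O)NC(CO)c1ccccc1`: > 3.33 h
Compound 2 `CCC(C)(C)C(=O)N(O)Cc1ccc(F)c(F)c1F`: 0.882 h

These two compounds were measured in an ADME assay on microsomes from liver (Homo sapiens) for metabolic stability, read by LC-MS, using NADPH; on this read-out lower numbers stand for a shorter-lived compound and higher numbers for a longer-lived compound. Compound 1 gives > 3.33 h, which is a limit of the assay and not a number. Among the compounds with values here, compound 2, at 0.882 h, therefore holds the only true number so far, and the other result is known only as the limit of > 3.33 h in this assay, at which 1 of the 2 values shown sits.

The next compound is compound 3 `CCC(C)(C)C(=O)N(O)Cc1ccc(F)cc1F`. It differs from compound 2 in a single place: hydrogen in place of fluoro on an aromatic carbon. In words, hydrogen stands in place of fluoro on an aromatic carbon, ortho to two fluoro groups and meta to a large group. Within the data shown here, no measured pair in this assay shows what such an exchange does, so the expectation rests on compound 2 at 0.882 h and on how small the structural change is. No clear direction is expected. The expected step, a 1.1-fold lower number from compound 2 to compound 3 (0.04 log units; within the scatter), stays within the usual scatter of the half-life read-out. For compound 3 the estimated half-life is 0.8 h, with an expected range from 0.38 h to 1.7 h.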

Compound 3, half-life: 3.3 h
The estimate for compound 3 lay 4.1-fold (0.62 log units) below the measured number; the whole stated range lies below it.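

Within the data shown here, until compound 3, no step between compounds differing in one place existed in this assay, so nothing showed whether this aromatic carbon had any bearing on half-life. The exchange of fluoro for hydrogen at this place, ortho to two fluoro groups and meta to a large group, gives a 3.7-fold higher number from compound 2 to compound 3 (0.57 log units; beyond the scatter), a modest step that lies beyond the usual scatter, so this single position does matter for the read-out even though only one heavy atom leaves and no hydrogen-bond donor, hydrogen-bond acceptor or net charge is involved. Compound 1, which differs from this pair in more than one place, gives a limit and not a number: the limit of > 3.33 h in this assay, at which 1 of the 3 values shown sits.

From the compounds shown here alone, the cause of the step remains open, as this single pair gives no measured property that could account for it, and it cannot say whether removing either of the other two fluoro groups would have a similar effect. Nor do the compounds shown tell how a chloro, methyl or methoxy group at this same aromatic carbon would compare with fluoro and hydrogen.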